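A few compounds are considered here, and "the series" means these few. Any claim that something is new, unique, unknown or untested is made for them only; others in the source may bear on it.

Measured so far in a physicochemical assay for lipophilicity, read by HPLC, at pH 7.4; on this read-out lower numbers stand for lower lipophilicity and higher numbers for higher lipophilicity:
compound 1 `CNCc1cn(S(=O)(=O)c2ccc(OC)cn2)c(-c2cccnc2F)c1F`: 0.64
compound 2 `CNCc1cn(S(=O)(=O)c2ccc(F)cn2)c(-c2cccnc2F)c1F`: 0.42
compound 3 `CNCc1cn(S(=O)(=O)c2cccnc2Cl)c(-c2cccnc2F)c1F`: 0.75

These three share one core and differ only in the group on the sulfonyl sulfur. Compound 3 stands clear of compound 2 but not of compound 1, and the two steps that show this are a number 0.33 log units higher from compound 2 to compound 3 (beyond the scatter) and a number 0.11 log units higher from compound 1 to compound 3 (within the scatter).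

The next compound is compound 4 `CNCc1cn(S(=O)(=O)c2cncc(Cl)c2)c(-c2cccnc2F)c1F`. It has the same atoms as compound 3, joined differently: 5-chloropyridin-3-yl in place of 2-chloropyridin-3-yl on a sulfonyl sulfur. Here 5-chloropyridin-3-yl takes the place of 2-chloropyridin-3-yl on a sulfonyl sulfur.

Going by the values given here, no measured pair shows this kind of rearrangement, so the evidence is indirect. The closest guides are the exchanges of one group for another in this small set. Besides the two steps above, there is a number 0.22 log units lower from compound 1 to compound 2 (within the scatter). Even these exchanges, which alter the group's make-up, gave steps that were within the scatter or only modest. The change to compound 4 alters no counted feature of the group, and the data favour no direction, so no step beyond the scatter is expected. The expected step is a number 0.05 log units higher from compound 3 to compound 4 (within the scatter). For compound 4 the estimated value is 0.8, with an expected range from 0.45 to 1.15.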

Compound 4, distribution coefficient: 1.44
Estimate against measurement, compound 4: 0.64 log units below; measured number above the stated range.
By their numbers in this assay, from the lowest: compounds 2, 1 and 3 (each within the scatter of the next, the first and the last beyond it); then compound 4.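

In this assay, the exchange of 2-chloropyridin-3-yl for 5-chloropyridin-3-yl on the sulfonyl sulfur gives a number 0.69 log units higher from compound 3 to compound 4 (beyond the scatter) even though both groups hold the same heavy atoms in the same kind of ring. So at this position, a rearrangement that leaves every counted feature of the group unchanged can still move the number beyond the scatter. Compound 4 also stands clear of the two compounds with other groups, with a number 1.02 log units higher from compound 2 to compound 4 (beyond the scatter) and a number 0.80 log units higher from compound 1 to compound 4 (beyond the scatter), and nothing shown gives a reason for the size of these steps.

On these data alone, this is a single pair of isomers, so it remains open whether rearranging the fluoro or methoxy pyridines would produce a step of similar size, or whether the result is particular to the chlorine-bearing ring. As far as these compounds go, it is also open whether a methyl group or a nitrile in place of the chlorine of 5-chloropyridin-3-yl, or a plain phenyl ring on the sulfonyl sulfur, would keep the number as high as that of compound 4.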